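The source may hold more compounds than are shown below. What is called first, only, known or untested is meant among the compounds shown, and "the series" means these compounds.

Compound 1 `Cc1ccn2cc(-c3ccc([N+](=O)[O-])cc3)nc2c1`: in a functional assay on HT-29 cells (Homo sapiens) for antiproliferative activity, read by MTT assay, with a stated time of 72 h (a higher number here means a weaker inhibitor of growth, a lower number a stronger inhibitor of growth), compound 1 gives > 100000 nM, which is a limit of the assay and not a number. Compound 2 `Cc1ccn2cc(-c3ccc(N)cc3)nc2c1`: in this assay compound 2 gives 93600 nM.

Within the data shown here, compound 2 thus holds the only number; the other value shown is a limit (the limit of > 100000 nM in this assay, at which 1 of the 2 values shown sits). Among the measured compounds shown here, the single measured step, an at least 1.0-fold lower number from compound 1 to compound 2 (0.02 log units; that floor lies within the scatter), lies within the scatter and gives no direction. Compound 3 `Cc1ccn2cc(-c3ccc(NCc4ccccc4)cc3)nc2c1` differs from compound 2 by benzyl in place of hydrogen on a nitrogen on an aromatic ring. For the measured compounds named here, no measured step bears on this change, since the one step measured concerns the nitro to amino exchange and not substitution on the amine nitrogen. With nothing to lean on, no shift beyond the scatter in this assay is expected, and the expected step of a 1.6-fold lower number from compound 2 to compound 3 (0.19 log units; within the scatter) is kept small. Compound 3 is estimated in this assay at 60000 nM, within 15000 nM to 150000 nM, with a fair chance that only a limit is returned.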

Compound 3, concentration for 50% growth inhibition: 17500 nM
The estimate for compound 3 lay 3.4-fold (0.54 log units) above the measured number, and the stated range covers the measured number.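

In this assay, among these compounds, substitution on the amine nitrogen is the first change to give a step beyond the scatter, with benzyl in place of hydrogen on a nitrogen on an aromatic ring giving a 5.3-fold lower number from compound 2 to compound 3 (0.73 log units; beyond the scatter). This nitrogen therefore accepts a benzyl group, and the unsubstituted amino group is not needed for the growth inhibition seen here, whereas the exchange of nitro for amino alone gave no readable direction. Benzylamino in place of nitro on an aromatic carbon gives an at least 5.7-fold lower number from compound 1 to compound 3 (0.75 log units; beyond the scatter), and that step is only a floor: the limit of > 100000 nM in this assay, at which 1 of the 3 values shown sits.

Whether the gain needs the aromatic ring of benzyl or follows from added carbon alone stays open, as a methyl group or a longer alkyl chain on the same nitrogen is absent from the compounds shown. Also open, on these data alone, are an acetyl amide at this nitrogen and a methoxy group or chlorine on the benzyl ring.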